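Lengthening the polyamine chain on two sulfonamide-capped scaffolds

This account rests on a few compounds, and the source may have more. Where it says the series, first, only, none or still open, it means among the compounds named here.

Measured compounds:
- compound 1, `CCCCCCCCCCCCS(=O)(=O)NCCCN(CCCNCCCCNCCCN)CCCNS(=O)(=O)CCCCCCCCCCCC`: 2270 nM
- compound 2, `CCCCCCCCCCCCCCCCS(=O)(=O)NCCCN(CCCNCCCCNCCCN)CCCNS(=O)(=O)CCCCCCCCCCCCCCCC`: 15100 nM
- compound 3, `CCCCCCCCCCCCS(=O)(=O)NCCCN(CCCNCCCNCCCCNCCCN)CCCNS(=O)(=O)CCCCCCCCCCCC`: 510 nM

These three compounds were tested in a functional assay on J774.1 cells (Mus musculus) for inhibition, read by Griess assay; on this read-out higher numbers stand for weaker inhibition and lower numbers for stronger inhibition. Compound 1 and compound 3 share a core and differ in one place: (4-((3-aminopropyl)amino)butyl)amino in place of ((3-aminopropyl)amino)methyl on a saturated chain carbon, three bonds along the chain from an amine nitrogen. That change made a step of a 4.5-fold lower number from compound 1 to compound 3 (0.65 log units; beyond the scatter). Compound 2 carries a different core; how its core differs from that of compound 1 is not broken down here, but in this assay compound 2 gave the highest number of the three, with compound 3 showing the lowest.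

Compound 4, `CCCCCCCCCCCCCCCCS(=O)(=O)NCCCN(CCCNCCCNCCCCNCCCN)CCCNS(=O)(=O)CCCCCCCCCCCCCCCC`, is not yet measured. It stands to compound 2 as compound 3 stands to compound 1, with the same change in the same place: (4-((3-aminopropyl)amino)butyl)amino in place of ((3-aminopropyl)amino)methyl on a saturated chain carbon, three bonds along the chain from an amine nitrogen. Because the change from compound 1 to compound 3 gave a 4.5-fold lower number from compound 1 to compound 3 (0.65 log units; beyond the scatter), a step of similar size is expected from compound 2 to compound 4, namely a 4.3-fold lower number from compound 2 to compound 4 (0.63 log units; beyond the scatter). On that basis compound 4 is estimated at 3500 nM in this assay, with a likely range from 1400 nM to 9000 nM.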

Compound 4, half-maximal inhibitory concentration: 5200 nM
Compound 4: the middle estimate sits 1.5-fold (0.17 log units) below what was measured; low and high end bracket the measured number.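

In this assay, swapping ((3-aminopropyl)amino)methyl for (4-((3-aminopropyl)amino)butyl)amino on the second core gave a 2.9-fold lower number from compound 2 to compound 4 (0.46 log units; beyond the scatter). The change therefore carried over from one core to the other, lowering the number on both by amounts that agree: the same change on two cores in this assay, a 4.5-fold lower number (0.65 log units; beyond the scatter) from compound 1 to compound 3 and a 2.9-fold lower number (0.46 log units; beyond the scatter) from compound 2 to compound 4, 1.5-fold (0.19 log units) apart, within the scatter of two such steps. Going by these compounds alone, this rests on only two matched pairs, so it does not show that the step would hold on other cores, nor does it explain why the number falls.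

The compounds shown leave open whether the step would survive with a shorter alkyl chain, such as octyl, on the sulfonyl groups. They also leave open what an amide in place of each sulfonamide would do.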